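Capping the ring amine of compound 3 with benzyloxycarbonyl

This account rests on a few compounds, and the source may have more. Where it says the series, first, only, none or still open, it means among the compounds named here.

Three compounds have numbers in a functional assay on MCF7 cells (Homo sapiens) for inhibition, read by MTT assay, with a stated time of 72 h; on this read-out higher numbers stand for weaker inhibition and lower numbers for stronger inhibition. Compound 1 `O=C(OCc1ccccc1)N1CCN(C(=S)SCc2cn(Cc3ccc(F)cc3)nn2)CC1` gives 10300 nM, and compound 2 `O=C(OCc1ccccc1)N1CCN(C(=S)SCc2cn(Cc3ccc(Cl)c(Cl)c3)nn2)CC1` gives 10600 nM; the step of a 1.0-fold higher number from compound 1 to compound 2 (0.01 log units; within the scatter) shows no movement beyond the scatter for that aryl swap. Compound 3 `S=C(SCc1cn(Cc2ccccc2Cl)nn1)N1CCNCC1` carries an uncapped ring amine and gives 38900 nM, the highest of the three numbers, beyond the scatter from both compound 1 and compound 2.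

Compound 4 `O=C(OCc1ccccc1)N1CCN(C(=S)SCc2cn(Cc3ccccc3Cl)nn2)CC1` differs from compound 3 by benzyloxycarbonyl in place of hydrogen on an amine nitrogen in a ring. Going by the values given here, no measured pair isolates this change, so its size is not directly known. Among the compounds with values here, what the numbers do show is that both capped compounds, compound 1 and compound 2, sit close together and well below compound 3, while the one measured step, a 1.0-fold higher number from compound 1 to compound 2 (0.01 log units; within the scatter), is within the scatter. Compound 4 is therefore expected to move toward the capped pair, a lower number by roughly a 3.2-fold lower number from compound 3 to compound 4 (0.51 log units; beyond the scatter). The estimate for compound 4 in this assay is 12000 nM, expected to fall between 5000 nM and 30000 nM.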

Compound 4, half-maximal inhibitory concentration: 21400 nM
For compound 4 the middle estimate is 1.8-fold (0.25 log units) below the measured one, and the stated range covers the measured number.
By their numbers in this assay, from the lowest: compounds 1 and 2 (each within the scatter of the next); then compounds 4 and 3 (each within the scatter of the next).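

In this assay, benzyloxycarbonyl in place of hydrogen on an amine nitrogen in a ring gives a 1.8-fold lower number from compound 3 to compound 4 (0.26 log units; within the scatter) and so, with the 2-chlorophenyl group held constant, this change alone does not separate the pair. With benzyloxycarbonyl held constant, the group on the saturated chain carbon bound to an aromatic nitrogen does register, modestly: 2-chlorophenyl in place of 3,4-dichlorophenyl gives a 2.0-fold higher number from compound 2 to compound 4 (0.31 log units; beyond the scatter) and 2-chlorophenyl in place of 4-fluorophenyl gives a 2.1-fold higher number from compound 1 to compound 4 (0.32 log units; beyond the scatter) in the same assay. No supporting data are available to account for either of these steps.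

Still open, from the compounds shown here alone, is whether an acetyl or a methyl group on that ring nitrogen would stand apart from compound 3 and compound 4. Also open, going by these compounds, is how a carboxylic acid or an amine on the phenyl ring would behave.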